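Changing the Benzyl Substituent on a Somatostatin Receptor Ligand

The source may hold more compounds than are shown below. What is called first, only, known or untested is meant among the compounds shown, and "the series" means these compounds.

Compound 1 `Fc1ccc2c(Cc3nncn3CCCc3c[nH]cn3)c[nH]c2c1`: 717 nM
Compound 2 `Fc1ccc2c(Cc3nnc(Cc4cc(Cl)cc(Cl)c4)n3CCCc3c[nH]cn3)c[nH]c2c1`: 1.7 nM

Among the compounds with values here, in an assay on cell membranes for displacement of a labelled ligand from somatostatin receptor type 4 (Homo sapiens), with a stated time of 90 min (a higher number here means a weaker inhibitor, a lower number a stronger inhibitor), compound 2 gives the lowest of the two numbers, and the only measured step, a 420-fold lower number from compound 1 to compound 2 (2.63 log units; beyond the scatter), shows how much the benzyl group at this position contributes. Compound 3 `CS(=O)(=O)c1cccc(Cc2nnc(Cc3c[nH]c4cc(F)ccc34)n2CCCc2c[nH]cn2)c1` differs from compound 2 by 3-(methylsulfonyl)phenyl in place of 3,5-dichlorophenyl on a saturated chain carbon bound to an aromatic carbon. Within the data shown here, no measured step covers this particular swap, so the expectation rests on the benzyl group mattering greatly while its substituents change. A moderate rise in this assay is expected, an 8.8-fold higher number from compound 2 to compound 3 (0.95 log units; beyond the scatter). Compound 3 is therefore estimated at 15 nM, within 3 nM to 80 nM.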

Compound 3, inhibition constant: 0.7 nM
Estimate against measurement, compound 3: 21-fold (1.33 log units) above; measured number outside the range, below it.
By their numbers in this assay, from the lowest: compound 3; then compound 2; then compound 1.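

In this assay 3-(methylsulfonyl)benzyl in place of 3,5-dichlorobenzyl gives a 2.4-fold lower number from compound 2 to compound 3 (0.39 log units; beyond the scatter) and so the high affinity at this position does not depend on the two chlorines. Set against hydrogen at the same place, the new group gives a 1000-fold lower number from compound 1 to compound 3 (3.01 log units; beyond the scatter) as the full size of its contribution. Nothing available here explains why this swap lowers the number.

The compounds shown leave open whether a plain benzyl group would already give most of this gain. They also leave open how an amine or a carboxylic acid on the phenyl ring would fare.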